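A few compounds are considered here, and "the series" means these few. Any claim that something is new, unique, unknown or untested is made for them only; others in the source may bear on it.

Of the compounds shown here, three measured so far share one core and differ only at the saturated ring and the group hanging from it. Compound 1 `c1ccc(CC2CCN(CCCc3c[nH]c4ccc(-n5cnnc5)cc34)CC2)cc1` gives 19 nM in an assay on CHO cells for displacement of a labelled ligand from 5-hydroxytryptamine receptor 1B (Homo sapiens); a lower number here means a stronger inhibitor, a higher number a weaker inhibitor. Compound 2 `FC1(Cc2ccccc2)CCN(CCCc2c[nH]c3ccc(-n4cnnc4)cc23)CC1` gives 15 nM in this assay, after a 1.3-fold lower number from compound 1 to compound 2 (0.10 log units; within the scatter). Compound 3 `FC1(Cc2ccccc2C(F)(F)F)CCN(CCCc2c[nH]c3ccc(-n4cnnc4)cc23)CC1` gives 14 nM in this assay, after a 1.1-fold lower number from compound 2 to compound 3 (0.03 log units; within the scatter). Compound 3 thus holds the lowest number of the three, but its gaps to compound 2 and to compound 1 both lie within the scatter, so the three cannot be set in order.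

Compound 4 `FC1(CCc2ccccc2)CCN(CCCc2c[nH]c3ccc(-n4cnnc4)cc23)CC1` is not yet measured. It differs from compound 3 in one place: benzyl in place of 2-(trifluoromethyl)phenyl on a saturated chain carbon bound to a saturated ring carbon. One part of this change is the reverse of a 1.1-fold lower number from compound 2 to compound 3 (0.03 log units; within the scatter), a step within the scatter. Among the measured compounds shown here, the other part, the longer chain to the aromatic ring, has no counterpart among the measured compounds, and the step from compound 1 to compound 2 does not bear on it. Because a 1.1-fold lower number from compound 2 to compound 3 (0.03 log units; within the scatter) lay within the scatter, compound 4 is expected to show a 1.3-fold higher number from compound 3 to compound 4 (0.11 log units; within the scatter), with the unprecedented chain extension widening the uncertainty. Compound 4 is estimated at 18 nM in this assay, within a range from 7 nM to 45 nM.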

Compound 4, half-maximal inhibitory concentration: 49 nM
For compound 4 the middle estimate is 2.7-fold (0.43 log units) below the measured one, and the stated range ends below it.
By their numbers in this assay, from the lowest: compounds 3, 2 and 1 (each within the scatter of the next); then compound 4.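

Among the compounds shown here, the earlier changes around the saturated ring left the number in this assay within the scatter, so this is the first change to move it beyond the scatter: a 3.3-fold higher number from compound 2 to compound 4 (0.51 log units; beyond the scatter), for benzyl in place of phenyl on a saturated chain carbon bound to a saturated ring carbon. The step read against the other neighbour, 2-(trifluoromethyl)benzyl to phenethyl, is of about the same size, a 3.5-fold higher number from compound 3 to compound 4 (0.54 log units; beyond the scatter), so both routes to compound 4 point the same way, and this position, unresponsive to the trifluoromethyl group in the step from compound 2 to compound 3, does respond to the phenethyl group, though only modestly. Nothing given here accounts for this rise.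

On these data alone, it remains open whether a still longer chain would raise the number further, or whether a trifluoromethyl group on the aromatic ring of compound 4 would leave it unchanged, as it did on the benzyl group. Also open, as far as these compounds go, is whether a hydrogen in place of the fluoro group, or an ether oxygen or a carbonyl in the chain, would change the number for the phenethyl series.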